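The source may hold more compounds than are shown below. What is called first, only, known or untested is meant among the compounds shown, and "the series" means these compounds.

The measured compounds:
Compound 1 `CC(C)N(Cc1cccc(OCCCCCC(=O)O)c1)C(=O)c1ccc(-c2ccsc2)cc1`. In an ADME assay on HEK293 cells (Homo sapiens) for cytotoxicity, read by CellTiter-Glo and resazurin assay, with a stated time of 72 h (on this read-out higher numbers stand for an effect only at larger amounts of compound and lower numbers for an effect already at smaller amounts), compound 1 gives > 26000 nM; this is a limit of the assay, not a number.
Compound 2 `CCOc1cccc(-c2ccc(C(=O)N(Cc3cccc(OCCCCCC(=O)O)c3)C(C)C)cc2)c1`. In this assay compound 2 gives > 20800 nM; this too is a limit of the assay.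
Compound 3 `CC(C)N(Cc1cccc(OCCCCCC(=O)O)c1)C(=O)c1ccc(-c2ccc3cc[nH]c3c2)cc1`. In this assay compound 3 gives > 26000 nM, again a limit of the assay.

Compound 1 thus stands at a limit, and the two further values shown are limits as well, so none of the three compounds produced a number in this assay. The steps a step that the two limits leave unreadable from compound 1 to compound 2 and a step that the two limits leave unreadable from compound 1 to compound 3 exchange the same group at the same aromatic carbon as the change studied here, yet neither can be read because the limit of > 26000 nM in this assay, at which 2 of the 3 values shown sit, and the limit of > 20800 nM in this assay, at which 1 of the 3 values shown sits, cap both ends of each step.

Compound 4 `CC(C)N(Cc1cccc(OCCCCCC(=O)O)c1)C(=O)c1ccc(-c2cccc(Cl)c2)cc1` differs from compound 1 in one place: 3-chlorophenyl in place of thiophen-3-yl on an aromatic carbon. Since every earlier exchange at this position left the read-out at a limit, no step beyond the scatter is expected in this assay, in either direction. Compound 4 is therefore expected to give about 30000 nM, within 15000 nM to 80000 nM, most likely reported as a limit. The estimated step that the limit leaves unreadable from compound 1 to compound 4 is expected to stay within the scatter.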

Compound 4, half-maximal effective concentration: > 21900 nM
Compound 4: a limit, no number (the forecaster's own chance of this, stated with the estimate: 85%); the middle value is on the limit's open side.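

Compound 4 also ends at a limit of the assay, so none of its steps to compound 1, compound 2 or compound 3 can be read. The compounds shown leave open at what concentration, if any, each would give an effect in this assay and whether exchanging the group on the aromatic carbon changes that concentration.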